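A Hydroxy Group Added to Compound 1

The source may hold more compounds than are shown below. What is called first, only, known or untested is meant among the compounds shown, and "the series" means these compounds.

Among the measured compounds shown here, in a functional assay on PA-1 cells (Homo sapiens) for cytotoxicity, read by MTT assay, with stated times of 6 h and 48 h (a lower number here means a stronger inhibitor, a higher number a weaker inhibitor), compound 1 `Cn1c(/C=C/C(=O)c2ccccc2O)cc(Br)c1Br` gives 1250 nM, and compound 2 `Cn1c(/C=C/C(=O)c2ccc(O)cc2O)cc(Br)c1Br` gives 830 nM, so the only two measured compounds lie within the usual scatter of each other. Compound 3 `Cn1c(/C=C/C(=O)c2cc(O)ccc2O)cc(Br)c1Br` has not yet been measured. It differs from compound 1 by hydroxy in place of hydrogen on an aromatic carbon, with the new group meta to a large group and para to a hydroxy group. For the measured compounds named here, compound 2 carries the same kind of change at another place, and that measured step, a 1.5-fold lower number from compound 1 to compound 2 (0.18 log units; within the scatter), is the only guide available. Since that step stayed within the scatter, no step beyond the scatter is expected in this assay, although a single example is thin evidence. The expected change is a 1.4-fold lower number from compound 1 to compound 3 (0.14 log units; within the scatter). For compound 3 the estimated value is 900 nM, with an expected range from 350 nM to 2300 nM.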

Compound 3, half-maximal inhibitory concentration: 380 nM
Compound 3: middle estimate off by 2.4-fold (0.37 log units), on the high side; the range from low to high includes it.
By their numbers in this assay, from the lowest: compound 3; then compounds 2 and 1 (each within the scatter of the next).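

In this assay, among the compounds shown here, hydroxy in place of hydrogen on the aromatic carbon that is meta to a large group and para to a hydroxy group gives a 3.3-fold lower number from compound 1 to compound 3 (0.52 log units; beyond the scatter) and is the first step to go beyond the scatter. The same kind of change at another place on the ring gave a 1.5-fold lower number from compound 1 to compound 2 (0.18 log units; within the scatter) and stayed within the scatter, so in these three compounds the size of the step depends on where the new hydroxy group sits. Nothing available here explains why this position gives the larger step.

On these data alone, whether the step needs a hydroxy group in particular remains open, since the effect of a methoxy group or an amine at this same position cannot be told from these compounds. As far as these compounds go, it is also open whether the step would hold on a different core.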